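Acetamido for hydroxy on the amide side chain

The compounds below may be only part of what the source reports. "The series", "measured", "known", "first", "only" and "open" are said of these compounds alone.

Measured compounds:
compound 1 `COc1nc(-c2cccs2)nc(C(=O)O)c1O` — "not determined" (no result reported)
compound 2 `O=C(NCCO)c1nc(-c2cccs2)[nH]c(=O)c1O` — > 100000 nM

Compound 1 carries a methoxy and a free acid on the shared core; in an assay on isolated protein for inhibition of deoxyribonuclease-1 (Homo sapiens) (a lower number here means a stronger inhibitor, a higher number a weaker inhibitor), compound 1 has "not determined" (no result reported). Compound 2 replaces those with a hydroxyethyl amide. In this assay compound 2 gives > 100000 nM, and this is a limit of the assay rather than a number. So among the two entries shown, compound 2 stands at the limit of > 100000 nM in this assay, at which 1 of the 2 values shown sits, with no measurable inhibition to build on.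

Compound 3 `CC(=O)NCCNC(=O)c1nc(-c2cccs2)[nH]c(=O)c1O` differs from compound 2 in one place: acetamido in place of hydroxy on a saturated chain carbon, two bonds along the chain from an amide-type nitrogen. The shared core and the amide linkage are untouched. Among the measured compounds shown here, since no measured pair frames this change, the most defensible expectation is no step beyond the scatter, with compound 3 staying where compound 2 sits.

In this assay compound 3 is therefore expected to show 150000 nM, within roughly 50000 nM to 500000 nM. The step from compound 2 is expected to be a step that the limit leaves unreadable from compound 2 to compound 3, most probably reported again only as a limit.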

Compound 3, half-maximal inhibitory concentration: 62600 nM
Compound 3: the middle estimate sits 2.4-fold (0.38 log units) above what was measured; the measured number falls inside the stated range.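

In this assay, compound 3 gives 62600 nM, the only single number among the compounds shown, so the end of the amide side chain is a place where a change can yield a readable value. Putting acetamido in place of hydroxy on a saturated chain carbon, two bonds along the chain from an amide-type nitrogen, gives an at least 1.5-fold lower number from compound 2 to compound 3 (0.20 log units; that floor lies within the scatter), which means that only a minimum for the step is known, and that minimum does not by itself clear the normal spread of repeated measurements. The full size of the step cannot be read, because the value of compound 2 is a limit of the assay and not a number: the limit of > 100000 nM in this assay, at which 1 of the 3 values shown sits.

The compounds shown leave open whether a longer chain carrying the acetamido group, or an amine or a carboxylic acid at the same chain end, would bring the number lower than that of compound 3. From the compounds shown here alone, whether the same swap would act in the same way on another core also stays open, as this change is seen in a single pair.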